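The source may hold more compounds than are shown below. What is called first, only, known or untested is meant among the compounds shown, and "the series" means these compounds.

Compound 1 `CCOC(=O)C1=C(C)NC(C)=C(C(=O)OC)C1c1cnc(SC)n1Nc1ccccc1` gives 1.66 nM in an assay on isolated protein (strain albino) for antagonist activity at Voltage-dependent L-type calcium channel subunit alpha-1C (Cavia porcellus); a higher number here means a weaker inhibitor, a lower number a stronger inhibitor.
Compound 2 `CCOC(=O)C1=C(C)NC(C)=C(C(=O)OCCOC)C1c1cnc(SC)n1Nc1ccccc1` gives 2.91 nM in this assay.

Among the compounds with values here, compound 2 stands beside compound 1 rather than apart from it: the single step of a 1.8-fold higher number from compound 1 to compound 2 (0.24 log units; within the scatter) lies within the scatter, so the two cannot be told apart on these numbers. Compound 3 `CCOC(=O)C1=C(C)NC(C)=C(C(=O)OCc2ccccc2)C1c1cnc(SC)n1Nc1ccccc1` differs from compound 2 by phenyl in place of methoxymethyl on a saturated chain carbon bound to an oxygen next to a carbonyl group. Within the data shown here, the only measured step at this part of the molecule, a 1.8-fold higher number from compound 1 to compound 2 (0.24 log units; within the scatter), was within the scatter, so the change to compound 3 is expected to shift this assay little, with a 1.2-fold higher number from compound 2 to compound 3 (0.08 log units; within the scatter) as the expected step. Compound 3 is estimated at 3.5 nM, between 1.2 nM and 10 nM.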

Compound 3, half-maximal inhibitory concentration: 1.86 nM
Compound 3: middle estimate off by 1.9-fold (0.27 log units), on the high side, within the range that was stated.
By their numbers in this assay, from the lowest: compounds 1, 3 and 2 (each within the scatter of the next).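

At this saturated chain carbon bound to an oxygen next to a carbonyl group, a six-membered aromatic ring now joins the open chain: in this assay phenyl in place of methoxymethyl gives a 1.6-fold lower number from compound 2 to compound 3 (0.19 log units; within the scatter) and phenyl in place of hydrogen gives a 1.1-fold higher number from compound 1 to compound 3 (0.05 log units; within the scatter). The three compounds therefore cannot be told apart on these numbers, even though the group entering here carries a ring and the earlier ones did not. No available evidence gives a reason for this result. From the compounds shown here alone, whether an amine or a carboxylic acid at this carbon would stay as close to these three remains open.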